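Chain-end swap in a weak alpha4/beta2 antagonist series

This account rests on a few compounds, and the source may have more. Where it says the series, first, only, none or still open, it means among the compounds named here.

Compound 1 `COc1ccc(OCCCCCN2CCCC(COC(=O)c3ccccc3N3C(=O)CC(C)C3=O)C2)cc1` is a weak antagonist: in an in vitro functional assay on HEK ts201 cells for antagonist activity at Neuronal acetylcholine receptor; alpha4/beta2 (Homo sapiens), read by fluorescence and calcium flux (on this read-out higher numbers stand for weaker inhibition and lower numbers for stronger inhibition), compound 1 gives 14500 nM, level with compound 3 `COc1ccc(OCCCCCN2CCCC(COC(=O)c3ccccc3-c3ccccc3)C2)cc1` at 14500 nM, and the two stand together as the lowest of three numbers; compound 2 `O=C(OCc1ccccc1-c1ccccc1)C1CCCN(CCCc2ccccc2)C1` sits at 17800 nM, within the scatter of both. For the measured compounds named here, the only single-point step seen so far, no change at the digits printed from compound 1 to compound 3 (within the scatter), lies on the aromatic ring of the ester and is flat. Compound 4 `CC1CC(=O)N(c2ccccc2C(=O)OCC2CCCN(CCCCOc3ccc(Cl)c(Cl)c3)C2)C1=O` alters a different region: 3,4-dichlorophenoxy in place of (4-methoxyphenoxy)methyl on a saturated chain carbon, four bonds along the chain from an amine nitrogen in a ring. Going by the values given here, no measured step touches this chain end, so the sole precedent is that one ring-side change left this assay untouched. On that basis the step of a 1.0-fold lower number from compound 1 to compound 4 (0.02 log units; within the scatter) is expected to be no change beyond the scatter, and compound 4 is estimated at 14000 nM, within 5000 nM to 40000 nM.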

Compound 4, half-maximal inhibitory concentration: 12300 nM
Beside the measured number, compound 4's estimate is 1.1-fold (0.06 log units) above it; low and high end bracket the measured number.
By their numbers in this assay, from the lowest: compounds 4, 1, 3 and 2 (each within the scatter of the next).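

In this assay, the step of a 1.2-fold lower number from compound 1 to compound 4 (0.07 log units; within the scatter) extends the flat behaviour seen on the ring side to this chain end. The swap to 3,4-dichlorophenoxy, with its two chlorines and no methoxy, stays within the scatter, so this position accepts both chain ends without a readable shift in the number. Nothing available here accounts for this result.

Because chain and ring substituents change together in this one step, their separate contributions remain unresolved. Also open, as far as these compounds go, is whether an amine or a carboxylic acid on the phenoxy ring, or a longer chain, would move the number beyond the scatter.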